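Following one swap on a weakly cytotoxic compound

The compounds below may be only part of what the source reports. "The series", "measured", "known", "first", "only" and "open" are said of these compounds alone.

- compound 1 `COc1ccc(C[C@H]2COC(=O)[C@@H]2Cc2ccc(OCc3cn(-c4ccc(F)cc4)nn3)c(OC)c2)cc1OC` gives >= 600000 nM as a limit of the assay
- compound 2 `CCN(CC)C(=O)CCC(=O)Oc1ccc(C[C@H]2C(=O)OC[C@@H]2Cc2ccc(OC)c(OC)c2)cc1OC` gives 213000 nM as a measured number
- compound 3 `COc1ccc(C[C@H]2COC(=O)[C@@H]2Cc2ccc(OCc3cn(-c4ccc(Br)cc4)nn3)c(OC)c2)cc1OC` gives 128000 nM as a measured number

In an ADME assay on HeLa cells (Homo sapiens) for cytotoxicity, read by MTT assay (on this read-out lower numbers stand for stronger inhibition and higher numbers for weaker inhibition), compound 2 (213000 nM) lies within the usual scatter of compound 3 (128000 nM), so these two numbers cannot be told apart. The entry for compound 1 (>= 600000 nM) is a limit and not a number.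

Compound 4 `COC(=O)[C@H](CC(C)C)NC(=O)CCC(=O)Oc1ccc(C[C@H]2C(=O)OC[C@@H]2Cc2ccc(OC)c(OC)c2)cc1OC` differs from compound 2 in a single group ((1-(methoxycarbonyl)-3-methylbutyl)amino in place of diethylamino on a carbonyl carbon), with (1-(methoxycarbonyl)-3-methylbutyl)amino in place of diethylamino on a carbonyl carbon. For the measured compounds named here, the only measured step between two close relatives (an at least 4.6-fold lower number from compound 1 to compound 3 (0.67 log units; beyond the scatter)) put bromo in place of fluoro on an aromatic carbon. It lies beyond the scatter, so one swap can move this read-out. However, it concerns a different group and gives no direction for the present change.

Going by the values given here, no step has been measured on this carbonyl carbon, so compound 4 is expected to stay close to compound 2 (213000 nM). The estimated step in this assay stays within the scatter (a 1.1-fold lower number from compound 2 to compound 4 (0.03 log units; within the scatter)). For compound 4 the estimated value is 200000 nM with an expected range from 70000 nM to 550000 nM as the likely span.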

Compound 4, half-maximal inhibitory concentration: 53200 nM
Beside the measured number, compound 4's estimate is 3.8-fold (0.58 log units) above it; the whole stated range lies above it.
By their numbers in this assay, from the lowest: compound 4; then compounds 3 and 2 (each within the scatter of the next). At a limit, above all of these: compound 1.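

In this assay, the change on this carbonyl carbon gives a 4.0-fold lower number from compound 2 to compound 4 (0.60 log units; beyond the scatter), the first measured sign that this read-out responds to a swap at this place and not only to bromo in place of fluoro on an aromatic carbon. The entering (1-(methoxycarbonyl)-3-methylbutyl)amino group differs from diethylamino in several ways at once, as it has more heavy atoms, a hydrogen-bond donor, hydrogen-bond acceptors and a defined stereocentre, so this single step cannot assign the change to any one of these features. Nothing measured in these compounds accounts for the lower number.

The compounds shown leave open which part of the entering group goes with the step, and whether its defined stereocentre matters. A carboxylic acid in place of the methyl ester, the opposite stereocentre, or a plain alkylamino chain with no ester would help to separate these features, while the same swap on a different side of the shared core would show whether the step holds beyond the pair of compound 2 and compound 4.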